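Adding a Chloro Group to Compound 2

This account rests on a few compounds, and the source may have more. Where it says the series, first, only, none or still open, it means among the compounds named here.

Of the compounds shown here, three have been measured in a functional assay on OVCAR-3 cells (Homo sapiens) for cytotoxicity, read by sulforhodamine B assay, with a stated time of 48 h; a lower number here means a stronger inhibitor of growth, a higher number a weaker inhibitor of growth. Compound 1 `ClCc1cccc(Cn2cnc3ncnc(Cl)c32)c1` gives 3230 nM in this assay. Compound 2 `ClCc1ccccc1Cn1cnc2ncnc(Cl)c21` has the same atoms joined differently, and the difference between the two cores is not broken down here; in this assay compound 2 gives 4160 nM, a value that lies within the scatter of the value of compound 1. Compound 3 `ClCc1cccc(Cn2cnc3nc(Cl)nc(Cl)c32)c1` gives 2880 nM in this assay.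

The change from compound 1 to compound 3 is chloro in place of hydrogen on an aromatic carbon, and it made a 1.1-fold lower number from compound 1 to compound 3 (0.05 log units; within the scatter). Compound 4 `ClCc1ccccc1Cn1cnc2nc(Cl)nc(Cl)c21`, not yet measured, is related to compound 2 by the same kind of change, (chloro in place of hydrogen on an aromatic carbon); the place of the entering chloro group is described in the same words for both pairs, so the change is the same in these two pairs, and it occurs nowhere else among the compounds shown.

Since the step of a 1.1-fold lower number from compound 1 to compound 3 (0.05 log units; within the scatter) lay within the scatter, the expected step to compound 4 is a 1.1-fold lower number from compound 2 to compound 4 (0.05 log units; within the scatter). The expected value of compound 4 in this assay is 3700 nM, estimated to fall between 1900 nM and 7400 nM. This expectation rests on the value 4160 nM of compound 2 and on the step of a 1.1-fold lower number from compound 1 to compound 3 (0.05 log units; within the scatter), and on nothing beyond these compounds.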

Compound 4, concentration for total growth inhibition: 27500 nM
Estimate against measurement, compound 4: 7.4-fold (0.87 log units) below; the measured number lies above the stated range.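

In this assay, chloro in place of hydrogen on an aromatic carbon, between two ring nitrogen atoms, gave a 6.6-fold higher number from compound 2 to compound 4 (0.82 log units; beyond the scatter), so compound 4 is a weaker inhibitor of growth than compound 2. Among these compounds, the same change did not behave alike on the two cores: the same change on two cores in this assay, a 1.1-fold lower number (0.05 log units; within the scatter) from compound 1 to compound 3 and a 6.6-fold higher number (0.82 log units; beyond the scatter) from compound 2 to compound 4, 7.4-fold (0.87 log units) apart, beyond the scatter of two such steps This shows that the step seen on the core of compound 1 cannot simply be carried over to the core of compound 2, but with only one pair on each core it does not show why the two steps part, nor does it give a rule for any other core or any other assay.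

The compounds shown leave open whether a further core would follow the pair of compound 1 and compound 3, with no step beyond the scatter, or the pair of compound 2 and compound 4, with a clear rise in the number. They also leave open whether another group entering at the same place, such as an amine or a methoxy group, would differ between the two cores in the same way as the chloro group.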